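A Methyl on an Amine Nitrogen, Carried Across Two Cores

The compounds below may be only part of what the source reports. "The series", "measured", "known", "first", "only" and "open" are said of these compounds alone.

Measured compounds:
Compound 1, `COc1ccc(C(=O)c2ccc3c(c2)C=CC(C)(C)O3)c(NC(=O)CN)c1`: 590 nM
Compound 2, `CNCC(=O)Nc1cc(OC)ccc1C(=O)c1ccc2c(c1)C=CC(C)(C)O2`: 850 nM
Compound 3, `C=C(c1ccc(OC)cc1NC(=O)CN)c1ccc(OC)c2c1OC(C)(C)C=C2`: 80 nM

In a functional assay on A2780 cells (Homo sapiens) for antiproliferative activity, read by MTT assay, with a stated time of 48 h (on this read-out higher numbers stand for weaker inhibition and lower numbers for stronger inhibition), compound 1 gives 590 nM and compound 2 gives 850 nM. The difference between them is methyl in place of hydrogen on an amine nitrogen, and the step it made was a 1.4-fold higher number from compound 1 to compound 2 (0.16 log units; within the scatter). Compound 3 gives 80 nM in this assay, the lowest of the three numbers and beyond the scatter from both others. The difference between the core of compound 3 and the core of compound 1 is not broken down here.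

Compound 4, `C=C(c1ccc(OC)cc1NC(=O)CNC)c1ccc(OC)c2c1OC(C)(C)C=C2`, is still to be measured in this assay. It differs from compound 3 by methyl in place of hydrogen on an amine nitrogen, the same change, at the same place, as that between compound 1 and compound 2. Because the earlier step was only a 1.4-fold higher number from compound 1 to compound 2 (0.16 log units; within the scatter), compound 4 is expected to sit a step of similar size away: a 1.4-fold higher number from compound 3 to compound 4 (0.14 log units; within the scatter). Compound 4 is therefore estimated at 110 nM, within a range from 50 nM to 250 nM.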

Compound 4, half-maximal inhibitory concentration: 210 nM
For compound 4 the middle estimate is 1.9-fold (0.28 log units) below the measured one; the measured number falls inside the stated range.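

In this assay methyl in place of hydrogen on an amine nitrogen gave a 2.6-fold higher number from compound 3 to compound 4 (0.42 log units; beyond the scatter) and this step can be set beside the one on the other core: the same change on two cores in this assay, a 1.4-fold higher number (0.16 log units; within the scatter) from compound 1 to compound 2 and a 2.6-fold higher number (0.42 log units; beyond the scatter) from compound 3 to compound 4, 1.8-fold (0.26 log units) apart, within the scatter of two such steps. For the compounds shown here, the change therefore carried from the core of compound 1 to the core of compound 3 without a difference in step size that stands clear of the scatter, although only the step on the core of compound 3 lies beyond the scatter on its own. Two pairs do not show that the step would stay similar on any further core, and they give no explanation for its size.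

The compounds shown leave open how ethylamino or dimethylamino in place of methylamino would behave on either core. They also leave open what a longer chain in place of the aminomethyl would do.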